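The compounds below may be only part of what the source reports. "The series", "measured", "known", "first", "only" and "open" are said of these compounds alone.

Compound 1 `Nc1nc(N)c2c(-c3ccsc3)cn([C@@H]3O[C@H](CO)[C@@H](O)[C@H]3O)c2n1` carries an amino group where compound 3 `COc1nc(N)nc2c1c(-c1ccsc1)cn2[C@@H]1O[C@H](CO)[C@@H](O)[C@H]1O` carries a methoxy group. In a functional assay on K562 cells (Homo sapiens), read by MTT assay, with a stated time of 72 h (a higher number here means a weaker inhibitor, a lower number a stronger inhibitor), compound 1 gives > 20000 nM, which is a limit of the assay and not a number. Compound 3 likewise gives > 20000 nM in this assay, again a limit. Compound 2 `Cc1ncnc2c1c(I)cn2[C@@H]1O[C@H](CO)[C@@H](O)[C@H]1O` gives 17800 nM in this assay. Going by the values given here, the one measured step, a step that the two limits leave unreadable from compound 1 to compound 3, cannot be sized because both values sit at the limit of > 20000 nM in this assay, at which 2 of the 3 values shown sit. Compound 1 therefore stands only at a limit among the numbers shown.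

Compound 4 `Nc1nc(N)c2c(-c3ccccc3)cn([C@@H]3O[C@H](CO)[C@@H](O)[C@H]3O)c2n1` differs from compound 1 by phenyl in place of thiophen-3-yl on an aromatic carbon. Among the compounds with values here, no measured step concerns this change, so no shift beyond the scatter is expected in either direction. Compound 4 is expected to give about 22000 nM in this assay, between 8000 nM and 60000 nM. That estimate means an expected step that the limit leaves unreadable from compound 1 to compound 4.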

Compound 4, half-maximal inhibitory concentration: > 20000 nM
Compound 4 gave a limit, no number (the forecaster's own chance of this, stated with the estimate: 65%); the middle value lies beyond the limit too.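

Compound 1 and compound 4 both sit at a limit rather than a number, so no step between them can be read: the limit of > 20000 nM in this assay, at which 3 of the 4 values shown sit.

The compounds shown leave open whether phenyl and thiophen-3-yl differ at all in this assay.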